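This account rests on a few compounds, and the source may have more. Where it says the series, first, only, none or still open, it means among the compounds named here.

Of the compounds shown here, three sharing one core have been measured in a physicochemical assay for lipophilicity; on this read-out higher numbers stand for higher lipophilicity and lower numbers for lower lipophilicity. Compound 1 `CC(/C=C/CC(C)CCCC(C)C)=C\C(=O)OC(C)C` gives 7.15, the highest of the three numbers. Compound 2 `CC(/C=C/CC(C)CCCC(C)(C)O)=C\C(=O)OC(C)C`, which carries a hydroxy in place of hydrogen on a saturated chain carbon bound to three saturated chain carbons, gives 5.06; that step is a number 2.09 log units lower from compound 1 to compound 2 (beyond the scatter). Compound 3 `COC(C)(C)C(O)CCC(C)C/C=C/C(C)=C/C(=O)OC(C)C` gives 3.86; from compound 1 this is a number 3.29 log units lower from compound 1 to compound 3 (beyond the scatter), and from compound 2 it is a number 1.20 log units lower from compound 2 to compound 3 (beyond the scatter). Every measured step thus brings a hydroxy or a methoxy onto the saturated chain, and every one lowers the number far beyond the scatter.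

Compound 4 `C=CCSC(=O)/C=C(C)/C=C/CC(C)CCCC(C)C` has not yet been measured. It differs from compound 1 in one place: allylsulfanyl in place of isopropoxy on a carbonyl carbon. The carbonyl carbon is left untouched in all three measured steps, and no hydroxy or methoxy comes or goes in this change, so none of those steps bears on it; they show only how strongly such groups move this read-out. With nothing comparable among the measured pairs, only a small step is expected in this assay, near the scatter and, if anything, upward, which is a number 0.25 log units higher from compound 1 to compound 4 (within the scatter). For compound 4 the expected value is 7.4, with a range from 6.8 to 8.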

Compound 4, partition coefficient: 7.97
Beside the measured number, compound 4's estimate is 0.57 log units below it, within the range that was stated.
By their numbers in this assay, from the lowest: compound 3; then compound 2; then compound 1; then compound 4.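

In this assay, the carbonyl carbon proves to be a place where a swap can raise the number: the step is a number 0.82 log units higher from compound 1 to compound 4 (beyond the scatter), whereas every earlier step was made on the saturated chain and went downward. This rise is modest beside those earlier falls, yet it comes without any change in the counts of heavy atoms, hydrogen-bond donors or hydrogen-bond acceptors, and neither group contains a ring. What does differ is the make-up of the group, with sulfur entering where oxygen leaves and allyl entering where isopropyl leaves, and nothing available accounts for the rise.

The compounds shown change the sulfur and the allyl together, so how much of the step belongs to each stays open; isopropylsulfanyl or allyloxy on the same carbonyl carbon would pull the two apart. Also open, on these data alone, is whether allylsulfanyl in place of isopropoxy gives a similar step when the saturated chain carries a hydroxy, as in compound 2.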